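The source may report more compounds than this note shows. Statements on the series, on what has been measured and on what is new or still open speak of the compounds shown alone.

Measured compounds in a functional assay on A549 cells (Homo sapiens) for cytotoxicity, read by MTT assay; on this read-out lower numbers stand for stronger inhibition and higher numbers for weaker inhibition:

compound 1, `CCOC(=O)C12C(=O)OCC=C1COC2c1ccccc1F` — > 1000000 nM.
compound 2, `CCOC(=O)C12C(=O)OCC=C1COC2c1ccc(F)cc1` — > 1000000 nM.

For compound 1 the value in this assay is a limit, not a number: > 1000000 nM. For compound 2 the value is likewise only a limit: > 1000000 nM. For the measured compounds named here, every value so far rests on (the limit of > 1000000 nM in this assay, at which 2 of the 2 values shown sit), so nothing can be said about where compound 2 stands relative to compound 1 beyond the fact that neither reaches a readable number. Going by the values given here, the only step between measured compounds, a step that the two limits leave unreadable from compound 1 to compound 2, is therefore of unknown size and direction.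

Compound 3, `CCOC(=O)C12C(=O)OCC=C1COC2c1ccc(Cl)cc1`, differs from compound 2 by chloro in place of fluoro on an aromatic carbon. Among the compounds with values here, no measured step bears on this exchange of halogen: the one step concerns the position of fluoro on the phenyl ring, not its identity, and it is unreadable in any case. With compound 2 at a limit, the step of a number no higher from compound 2 to compound 3 (the limit leaves the size open) is expected to be nil for practical purposes, and compound 3 is expected to return a limit as well. The estimate for compound 3 in this assay is 1000000 nM, in the range 300000 nM to 3000000 nM.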

Compound 3, half-maximal inhibitory concentration: > 1000000 nM
Compound 3: only a limit was reported; the forecaster's own chance of this, stated with the estimate: 85%; the middle value sits exactly at the limit.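

In this assay compound 3 gives > 1000000 nM, a limit and not a number. No step among compound 1, compound 2 and compound 3 can be read, as all three values are limits: the limit of > 1000000 nM in this assay, at which 3 of the 3 values shown sit.

The compounds shown leave open whether any substituent on the phenyl ring of the shared core gives a readable value in this assay.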